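The source may hold more compounds than are shown below. What is called first, only, known or untested is meant among the compounds shown, and "the series" means these compounds.

Working notes on the series in a functional assay on HCT-116 cells (Homo sapiens), read by MTT assay, with a stated time of 72 h; a higher number here means a weaker inhibitor, a lower number a stronger inhibitor.

Compound 2 `COc1ncnc2c1c(-c1ccoc1)cn2[C@@H]1O[C@H](CO)[C@@H](O)[C@H]1O` gives 110 nM in this assay and stands at the lowest of the two numbers that are known, with compound 1 `COc1ncnc2c1c(-c1ccsc1)cn2[C@@H]1O[C@H](CO)[C@@H](O)[C@H]1O` nearest at 120 nM. The step of a 1.1-fold lower number from compound 1 to compound 2 (0.04 log units; within the scatter) lies within the scatter, so the two are not told apart. Compound 3 `Cc1ncnc2c1c(-c1ccoc1)cn2[C@@H]1O[C@H](CO)[C@@H](O)[C@H]1O` returns only a limit of the assay, > 20000 nM, as noted in the limit of > 20000 nM in this assay, at which 1 of the 3 values shown sits. Within the data shown here, the step of an at least 180-fold higher number from compound 2 to compound 3 (2.25 log units; beyond the scatter) is the one large change seen so far; it sits at the methoxy position and not at the five-membered ring.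

Compound 4 `COc1ncnc2c1c(-c1cccs1)cn2[C@@H]1O[C@H](CO)[C@@H](O)[C@H]1O` has not yet been measured. Its difference from compound 2 is thiophen-2-yl in place of furan-3-yl on an aromatic carbon. Among the measured compounds shown here, the only measured step that bears on this position is a 1.1-fold lower number from compound 1 to compound 2 (0.04 log units; within the scatter), where thiophen-3-yl and furan-3-yl gave numbers within the scatter of each other. For the measured compounds named here, no measured step covers thiophen-2-yl, so the move of the ring attachment point is untested here. On that basis the step from compound 2 to compound 4 in this assay is expected to be a 1.2-fold higher number from compound 2 to compound 4 (0.07 log units; within the scatter), with no change beyond the scatter anticipated. The estimate for compound 4 in this assay is 130 nM, with a range from 55 nM to 320 nM.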

Compound 4, half-maximal inhibitory concentration: 80 nM
Compound 4: middle estimate off by 1.6-fold (0.21 log units), on the high side, and the stated range covers the measured number.
By their numbers in this assay, from the lowest: compounds 4, 2 and 1 (each within the scatter of the next). At a limit, above all of these: compound 3.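

In this assay, among these compounds, the earlier compounds compared only thiophen-3-yl with furan-3-yl, whereas thiophen-2-yl now also changes the ring atom through which the five-membered aromatic ring is attached to the core; the two new steps, a 1.4-fold lower number from compound 2 to compound 4 (0.14 log units; within the scatter) and a 1.5-fold lower number from compound 1 to compound 4 (0.18 log units; within the scatter), both stay within the scatter. Among the compounds shown here, compound 1, compound 2 and compound 4 are therefore not told apart, so at this aromatic carbon neither the swap of sulfur for oxygen nor the change of attachment point moves the number beyond the scatter in the three rings compared, and the only large step remains the one at the methoxy position. Nothing at hand gives a cause for this flat result.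

From the compounds shown here alone, whether this position would accept something other than a five-membered aromatic ring with one hetero atom remains open, for example a phenyl ring, an amine, a carboxylic acid or a longer alkyl chain. Going by these compounds, it is also open whether the large step at the methoxy position would recur with thiophen-2-yl in place of furan-3-yl.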